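The source may hold more compounds than are shown below. What is called first, only, known or untested is meant among the compounds shown, and "the series" means these compounds.

Measured so far:
compound 1 `Cc1cc(C(=O)NCN2CCC(c3cccc[n+]3[O-])CC2)ccc1F` with 67%
compound 2 `COc1ccccc1C1CCN(CC(=O)Nc2cccc(C)c2)CC1` with 43%
compound 3 `O=C(CN1CCC(c2cccc[n+]2[O-])CC1)NC1CCCCC1` with 58%

In a functional assay on HEK293 cells for agonist activity at D(4) dopamine receptor (Homo sapiens), read by FLIPR (on this read-out higher numbers stand for larger maximal responses and lower numbers for smaller maximal responses), compound 1 gives 67%, compound 3 gives 58% and compound 2 gives 43%. Compound 2 thus stands lowest of the three; its nearest neighbour is compound 3, whose number is higher by a margin beyond the usual scatter, and compound 1 lies further above it, again beyond the scatter. No single-change step between any two of the measured compounds is available, so how much one exchange of a group moves the largest response in this assay has not been shown directly.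

Compound 4 `Cc1cccc(NC(=O)CN2CCC(c3cccc(O)c3)CC2)c1` is the next compound to be measured. It differs from compound 2 in one place: 3-hydroxyphenyl in place of 2-methoxyphenyl on a saturated ring carbon. Going by the values given here, since no comparable step is known, the direction of the change in this assay is uncertain; a modest upward step from compound 2 is expected, and the step of a number 7 percentage points higher from compound 2 to compound 4 (within the scatter) is her estimate. For compound 4 the largest response is expected to come to about 50%, within a range from 30% to 70%.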

Compound 4, largest response reached (reported as efficacy), in percent of the reference or control that the assay uses: 66%
The estimate for compound 4 lay 16 percentage points below the measured number; the range from low to high includes it.
By their numbers in this assay, from the lowest: compound 2; then compounds 3, 4 and 1 (each within the scatter of the next).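

In this assay the exchange of 2-methoxyphenyl for 3-hydroxyphenyl on a saturated ring carbon gives a number 23 percentage points higher from compound 2 to compound 4 (beyond the scatter) and so supplies the only single-change step shown. This position, three ring bonds from the ring nitrogen, therefore responds to the group it carries, since one exchange with the rest of the molecule unchanged moves the largest response beyond the scatter. The entering group brings a hydrogen-bond donor that the leaving group lacks, and its oxygen-bearing substituent also differs in kind and in place, but no measurement available here bears on the cause of the step.

As far as these compounds go, whether the step belongs to the hydroxyl or to its place on the ring stays open, and 3-methoxyphenyl or 2-hydroxyphenyl at this carbon would separate the two. Also open, from the compounds shown here alone, is how an aminophenyl or a carboxyphenyl group would fare here.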